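Diacylhydrazide in place of arylhydrazide on a sulfonamide core

The source may report more compounds than this note shows. Statements on the series, on what has been measured and on what is new or still open speak of the compounds shown alone.

Measured compounds:
compound 1, `O=C(NNc1ccccc1Cl)c1ccccc1NS(=O)(=O)c1cnc(O)nc1O`, 14100 nM
compound 2, `O=C(NNC(=O)c1ccc(NS(=O)(=O)c2cnc(O)nc2O)cc1)c1ccc(F)cc1`
compound 3, `O=C(NNC(=O)c1cccc(NS(=O)(=O)c2cnc(O)nc2O)c1)c1cccc(Cl)c1`, 13500 nM

Of the compounds shown here, three sharing the sulfonamide-bearing core have been tested in a functional assay on OVCAR-3 cells (Homo sapiens) for antiproliferative activity, read by MTT assay, with a stated time of 24 h; a higher number here means a weaker inhibitor, a lower number a stronger inhibitor. Compound 1 gives 14100 nM and sits at the higher of the two numbers available, although compound 3 at 13500 nM lies within the usual scatter of it, so the two cannot be ordered. Compound 2 reaches only the limit of the measurement, > 20000 nM, and no number is known for it; this is the limit described as the limit of > 20000 nM in this assay, at which 1 of the 3 values shown sits.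

The next compound, compound 4, `O=C(NNC(=O)c1ccccc1NS(=O)(=O)c1cnc(O)nc1O)c1ccccc1F`, has not yet been measured. Compared with compound 1 the change is (2-fluorophenyl)carbonyl in place of 2-chlorophenyl on an amine nitrogen. Going by the values given here, no step between measured compounds isolates this change. What the measured compounds show is that the two diacylhydrazides, compound 2 and compound 3, are no stronger than the arylhydrazide compound 1, with one of them at the limit. Compound 4 is therefore expected to remain a weak inhibitor, and the step of a 1.1-fold higher number from compound 1 to compound 4 (0.05 log units; within the scatter) is estimated to fall within the scatter or slightly toward a higher number. Compound 4 is expected to give about 16000 nM, in the range 6000 nM to 40000 nM.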

Compound 4, half-maximal inhibitory concentration: 15300 nM
For compound 4 the middle estimate is 1.0-fold (0.02 log units) above the measured one; low and high end bracket the measured number.
By their numbers in this assay, from the lowest: compounds 3, 1 and 4 (each within the scatter of the next). At a limit, above all of these: compound 2.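

In this assay, going by these compounds alone, the step of a 1.1-fold higher number from compound 1 to compound 4 (0.04 log units; within the scatter) is the first that isolates a change at this position, and it lies within the scatter, so compound 1 and compound 4 cannot be told apart. On this amine nitrogen, whose other neighbour is an amide-type nitrogen, the assay therefore does not distinguish 2-chlorophenyl from (2-fluorophenyl)carbonyl, even though the entering group adds a carbonyl and a hydrogen-bond acceptor and carries fluorine where the leaving group carries chlorine. Nothing measured here bears on why these two groups read alike.

The compounds shown leave open how the carbonyl and the exchange of chlorine for fluorine each contribute to this step, since the two differences arrive together and (2-chlorophenyl)carbonyl on the same nitrogen would be needed to separate them. Also open, as far as these compounds go, is whether any group at this position can move the number clearly away from this level, for instance an acetyl group, a longer alkyl chain, or an amine or a carboxylic acid on the aromatic ring of the entering group.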